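This account rests on a few compounds, and the source may have more. Where it says the series, first, only, none or still open, it means among the compounds named here.

Measured compounds:
compound 1, `CC(=O)NC1CCN(c2nc3c(c(Nc4ccc(C(F)(F)F)cc4)n2)CCN(c2ncccc2C(F)(F)F)CC3)C1`, with 19 ug/mL in a physicochemical assay for solubility, in simulated intestinal fluid, measured as thermodynamic solubility, at pH 6.8; on this read-out higher numbers stand for higher solubility and lower numbers for lower solubility;
compound 2, `CCC(CC)N1CCN(c2nc3c(c(Nc4ccc(C(F)(F)F)cc4)n2)CCN(c2ncccc2C(F)(F)F)CC3)CC1`, with 109 ug/mL in this assay.

Within the data shown here, compound 2 holds the highest of the two numbers so far; its nearest neighbour is compound 1, and the step of a 5.7-fold higher number from compound 1 to compound 2 (0.76 log units; beyond the scatter) separates them. The next compound, compound 3, is `CN(c1nc2c(c(Nc3ccc(C(F)(F)F)cc3)n1)CCN(c1ncccc1C(F)(F)F)CC2)C1CCCNC1`. It differs from compound 2 in one place: methyl(piperidin-3-yl)amino in place of 4-(pentan-3-yl)piperazin-1-yl on an aromatic carbon.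

Among the measured compounds shown here, only one measured step touches the same position, and it is the step of a 5.7-fold higher number from compound 1 to compound 2 (0.76 log units; beyond the scatter), a modest change for a substituent swap at that aromatic carbon. For the measured compounds named here, since compound 3 keeps a six-membered non-aromatic ring with a nitrogen atom attached through that position, as compound 2 does, and since no measured pair shows what the methyl(piperidin-3-yl)amino group itself does, the expected step of a 1.0-fold higher number from compound 2 to compound 3 (0.00 log units; within the scatter) is small, with no clear direction beyond the scatter. Compound 3 is therefore estimated at 110 ug/mL, within a range from 35 ug/mL to 350 ug/mL.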

Compound 3, solubility: 211 ug/mL
The estimate for compound 3 lay 1.9-fold (0.28 log units) below the measured number, within the range that was stated.
By their numbers in this assay, from the lowest: compound 1; then compounds 2 and 3 (each within the scatter of the next).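

At the aromatic carbon between two ring nitrogen atoms, methyl(piperidin-3-yl)amino in place of 4-(pentan-3-yl)piperazin-1-yl gives a 1.9-fold higher number from compound 2 to compound 3 (0.29 log units; within the scatter) in this assay, so two groups that differ in heavy atoms, ring hetero atoms and hydrogen-bond donors are not separated by this read-out. Against 3-acetamidopyrrolidin-1-yl, the new group gives an 11-fold higher number from compound 1 to compound 3 (1.05 log units; beyond the scatter) and thereby shows that the gap first seen with compound 2 does not belong to 4-(pentan-3-yl)piperazin-1-yl alone, since compound 1 now stands apart from two different groups at this position. Nothing available bears on the reason for these numbers.

Because 3-acetamidopyrrolidin-1-yl carries both an acetamide and a pyrrolidine ring, the three compounds leave open which of the two sets compound 1 apart, and an acetyl group on the ring nitrogen of the piperidin-3-yl group would be one way to separate them. As far as these compounds go, it is also open whether a morpholine or an open-chain dialkylamine at this carbon would fall with compounds 2 and 3 or with compound 1.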